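Methyl in Place of Hydrogen on the Phenyl Ring

A few compounds are considered here, and "the series" means these few. Any claim that something is new, unique, unknown or untested is made for them only; others in the source may bear on it.

Measured so far:
compound 1 `O=S(=O)(CC1=NCCO1)c1n[nH]cc1-c1ccccc1`: 50.6%
compound 2 `O=S(=O)(CC1=NCCS1)c1n[nH]cc1-c1ccccc1`: "not active" (no number reported)

In a functional assay, read by Griess assay, with a stated time of 150 min, tested at 50 ug/mL (a lower number here means a weaker effect, a higher number a stronger effect of the compound at the concentration tested), compound 1 gives 50.6%. For the measured compounds named here, this is the only number in the set; compound 2 is recorded only as "not active" (no number reported), with no value attached, so nothing beyond that can be drawn from the pair. Compound 1 therefore stands alone as the sole reference point for this assay.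

Compound 3 `Cc1ccc(-c2c[nH]nc2S(=O)(=O)CC2=NCCO2)cc1` differs from compound 1 in a single place: methyl in place of hydrogen on an aromatic carbon. Going by the values given here, no pair of measured compounds shows a step of any kind, so the size of this change cannot be read from the data. Given that, the step from compound 1 to compound 3 is expected to be a number 2.6 percentage points lower from compound 1 to compound 3 (within the scatter), a change that is expected to stay within the scatter of this assay rather than point clearly up or down. On this basis compound 3 is estimated at 48% in this assay, with a range from 25% to 70% to reflect the absence of any measured step to lean on.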

Compound 3, a percentage reported as activity, at one concentration (the size of the read-out at that concentration, not a potency): 59.4%
For compound 3 the middle estimate is 11.4 percentage points below the measured one; the range from low to high includes it.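

Methyl in place of hydrogen on an aromatic carbon, para to a large group, gives a number 8.8 percentage points higher from compound 1 to compound 3 (within the scatter) in this assay, the first step in the set that can be read from two measured compounds. The read-out therefore does not separate the phenyl of compound 1 from the 4-methylphenyl of compound 3, and this position accepts a methyl without a loss that stands clear of the usual scatter, something compound 1 and its unquantified neighbour could not show. No measurement is at hand that would explain this result.

The compounds shown leave open whether this position would accept anything other than a methyl, such as a chlorine atom, a methoxy group, an amine, a carboxylic acid or a longer chain, and whether any of these would move the read-out beyond the scatter. They also leave open what a methyl would do on the other carbons of the six-membered ring, and whether the same exchange would mean anything on the sulfur-containing ring of the inactive neighbour.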